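Sulfone series: pyridin-3-yl in place of 4-bromophenyl

The compounds below may be only part of what the source reports. "The series", "measured", "known", "first", "only" and "open" are said of these compounds alone.

Compound 1, `COc1ccc(S(=O)(=O)c2ccc(NC(=O)C(C)(O)C(F)(F)F)cc2)cc1`: in a functional assay (Cavia porcellus) with sulfonylurea receptors; K-ATP channels (Homo sapiens) as the target (on this read-out higher numbers stand for weaker inhibition and lower numbers for stronger inhibition), compound 1 gives > 30000 nM, which is a limit of the assay.
Compound 2, `Cc1ccc(S(=O)(=O)c2ccc(NC(=O)C(C)(O)C(F)(F)F)cc2)cc1`: in this assay compound 2 gives > 30000 nM, again a limit of the assay.
Compound 3, `CC(O)(C(=O)Nc1ccc(S(=O)(=O)c2ccc(Br)cc2)cc1)C(F)(F)F`: in this assay compound 3 gives > 30000 nM, also a limit of the assay.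

Compound 3 thus stands at the limit of this assay (the limit of > 30000 nM in this assay, at which 3 of the 3 values shown sit), where every measured value of the series sits. The steps between the measured compounds, a step that the two limits leave unreadable from compound 1 to compound 2, a step that the two limits leave unreadable from compound 1 to compound 3 and a step that the two limits leave unreadable from compound 2 to compound 3, have no readable size. Compound 4, `CC(O)(C(=O)Nc1ccc(S(=O)(=O)c2cccnc2)cc1)C(F)(F)F`, differs from compound 3 in one place: pyridin-3-yl in place of 4-bromophenyl on a sulfonyl sulfur. For the measured compounds named here, no measured step bears on this change, and no measured step has a readable size at all. None of the three measured compounds shows inhibition within the measurable window of this assay. Compound 4 is therefore expected to remain at the limit, estimated at 30000 nM with a range from 10000 nM to 100000 nM. The expected step is a number no higher from compound 3 to compound 4 (the limit leaves the size open), none beyond the scatter.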

Compound 4, half-maximal inhibitory concentration: 3500 nM
Estimate against measurement, compound 4: 8.6-fold (0.93 log units) above, and the stated range ends above it.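

In this assay, the group on the sulfonyl sulfur now proves able to move the read-out: pyridin-3-yl gives an at least 8.5-fold lower number from compound 3 to compound 4 (0.93 log units; beyond the scatter), and the comparisons with the other two aryl groups give an at least 8.5-fold lower number from compound 2 to compound 4 (0.93 log units; beyond the scatter) and an at least 8.5-fold lower number from compound 1 to compound 4 (0.93 log units; beyond the scatter). These sizes are minimum sizes, and the steps among compound 1, compound 2 and compound 3 still cannot be read. Compound 4 is the only compound shown with a reading inside the measurable window, and it is also the only one with a hetero atom in this ring: the limit of > 30000 nM in this assay, at which 3 of the 4 values shown sit.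

The compounds shown do not separate the ring nitrogen from the loss of the bromo, methyl or methoxy group, a question that an unsubstituted phenyl on the sulfonyl sulfur would address. On these data alone, whether a pyrimidinyl ring would give a lower number than pyridin-3-yl also stays open.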